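The source may report more compounds than this note shows. Statements on the series, on what has been measured and on what is new or still open speak of the compounds shown alone.

Series notes. Compound 1 `Cc1cc(CCC(=O)O)ccc1-c1noc(-c2ccc(OC(C)C)c(C(F)(F)F)c2)n1`, compound 2 `CCOc1ccc(-c2nc(-c3ccc(CCC(=O)O)cc3C)no2)cc1C(F)(F)F` and compound 3 `Cc1cc(CCC(=O)O)ccc1-c1noc(-c2ccc(OC(C)C)c(C#N)c2)n1` have been run in a functional assay on CHO cells with sphingosine 1-phosphate receptor 2 (Homo sapiens) as the target, read by GTPgammaS binding; on this read-out higher numbers stand for an effect only at larger amounts of compound and lower numbers for an effect already at smaller amounts. In this assay compound 1 returns only a limit, > 10000 nM. Compound 2 likewise returns only a limit, > 10000 nM. Compound 3 also stops at a limit, > 10000 nM. The change from compound 2 to compound 1 is methyl in place of hydrogen on a saturated chain carbon bound to an oxygen on an aromatic ring and a saturated chain carbon, and in this assay it reads a step that the two limits leave unreadable from compound 2 to compound 1. The change from compound 1 to compound 3 reads a step that the two limits leave unreadable from compound 1 to compound 3. Compound 2 and compound 3 differ in more than one place; the difference between the two cores is not broken down here. All three values sit at the limit of > 10000 nM in this assay, at which 3 of the 3 values shown sit.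

Compound 4 `CC[C@H](C)Oc1ccc(-c2nc(-c3ccc(CCC(=O)O)cc3C)no2)cc1C#N` is not yet measured. It differs from compound 3 by methyl in place of hydrogen on a saturated chain carbon, two bonds along the chain from an oxygen on an aromatic ring. This is the same kind of change as that from compound 2 to compound 1, made twice among the compounds shown, but the place is not the same: there the carbon is bound to an oxygen on an aromatic ring and a saturated chain carbon, here it lies two bonds along the chain from an oxygen on an aromatic ring. The earlier step gave no readable size. In this assay the expected step is a step that the limit leaves unreadable from compound 3 to compound 4, because compound 3 sits at the limit of > 10000 nM in this assay, at which 3 of the 3 values shown sit. Compound 4 is expected at 15000 nM, with a range of 4000 nM to 60000 nM, most likely again only as a limit.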

Compound 4, half-maximal effective concentration: > 10000 nM
Compound 4: only a limit was reported (the forecaster's own chance of this, stated with the estimate: 80%); the middle value lies beyond the limit too.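

In this assay compound 3 and compound 4 both return only a limit, so the change from isopropoxy to sec-butoxy gives no readable step; all values shown sit at one limit: the limit of > 10000 nM in this assay, at which 4 of the 4 values shown sit.

The compounds shown leave open whether any member of this series reaches a measurable value in this assay, and what size any of these changes has there.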